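The source may hold more compounds than are shown below. What is called first, only, known or untested is meant among the compounds shown, and "the series" means these compounds.

In a functional assay on SW-620 cells (Homo sapiens) for antiproliferative activity, read by MTT assay, with a stated time of 24 h (on this read-out lower numbers stand for stronger inhibition and higher numbers for weaker inhibition), compound 1 `CCN(CC)c1ccc(/C=C/C(=O)c2ccc(OC)c3c2OC(C)(C)C=C3)cc1` gives 670 nM, while compound 2 `COc1ccc(C(=O)/C=C/c2ccc([N+](=O)[O-])cc2)c2c1C=CC(C)(C)O2` gives 3520 nM, the higher of the two numbers. Compound 3 `COc1ccc(C(=O)/C=C/c2ccc(C(F)(F)F)cc2)c2c1C=CC(C)(C)O2` has trifluoromethyl in place of nitro on an aromatic carbon, para to a large group (trifluoromethyl in place of nitro on an aromatic carbon). Going by the values given here, the only measured step, a 5.3-fold higher number from compound 1 to compound 2 (0.72 log units; beyond the scatter), is modest and replaces diethylamino with nitro, and no measurement yet covers trifluoromethyl. Among the compounds with values here, with that step as the sole guide, no change beyond the scatter is expected in this assay, so the direction stays open. The expected change is a 1.2-fold lower number from compound 2 to compound 3 (0.07 log units; within the scatter). Compound 3 is estimated at 3000 nM, with an expected range from 1100 nM to 8000 nM.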

Compound 3, half-maximal inhibitory concentration: > 10000 nM
Compound 3: a limit, no number (the forecaster's own chance of this, stated with the estimate: 8%); at least 3.3-fold (0.52 log units) between middle value and limit.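

In this assay compound 3 gives > 10000 nM, a limit and not a number. At this position, para to a large group, trifluoromethyl in place of nitro gives an at least 2.8-fold higher number from compound 2 to compound 3 (0.45 log units; beyond the scatter), and trifluoromethyl in place of diethylamino gives an at least 14-fold higher number from compound 1 to compound 3 (1.17 log units; beyond the scatter). The group at this one position is thus enough to set all three compounds apart, though the full size of both steps stays unread: the limit of > 10000 nM in this assay, at which 1 of the 3 values shown sits.

Still open, on these data alone, is where a smaller amine, such as dimethylamino, or a carboxylic acid would fall at this position.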